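The source may hold more compounds than are shown below. What is called first, only, known or untested is meant among the compounds shown, and "the series" means these compounds.

In a functional assay on M21 cells (Homo sapiens) for antiproliferative activity, read by sulforhodamine B assay, with a stated time of 48 h (on this read-out lower numbers stand for stronger inhibition and higher numbers for weaker inhibition), the numbers so far are:

- Compound 1 `CCCCc1ccc(NS(=O)(=O)c2ccc(N3CCNC3=O)cc2)cc1` gives 450 nM
- Compound 2 `CCc1ccc(NS(=O)(=O)c2ccc(N3CCNC3=O)cc2)cc1` gives 480 nM
- Compound 3 `O=C1NCCN1c1ccc(S(=O)(=O)Nc2ccc(Br)cc2)cc1` gives 130 nM

Compound 3 has the lowest of these three numbers. Putting bromo in place of an alkyl chain gave two modest steps, both beyond the scatter (a 3.5-fold lower number from compound 1 to compound 3 (0.54 log units; beyond the scatter) and a 3.7-fold lower number from compound 2 to compound 3 (0.57 log units; beyond the scatter)). The butyl and ethyl chains themselves cannot be told apart (a 1.1-fold higher number from compound 1 to compound 2 (0.03 log units; within the scatter)).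

Compound 4 `CC(C)Cc1ccc(NS(=O)(=O)c2ccc(N3CCNC3=O)cc2)cc1` reverses that kind of swap, with isobutyl in place of bromo on an aromatic carbon. No branched chain has been measured yet, so the two bromo steps, read backwards, are the closest guide. In this assay a modest step of similar size is therefore expected, towards a higher number and so weaker inhibition, which would put compound 4 near compound 1 and compound 2. The estimate amounts to an expected step (a 3.5-fold higher number from compound 3 to compound 4 (0.54 log units; beyond the scatter)) of that size. The estimated value for compound 4 is 450 nM, with an expected range from 200 nM to 1000 nM in this assay.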

Compound 4, half-maximal inhibitory concentration: > 1000 nM
Compound 4 gave a limit, no number; the forecaster's own chance of this, stated with the estimate: 2%; middle value at least 2.2-fold (0.34 log units) away from the limit.
By their numbers in this assay, from the lowest: compound 3; then compounds 1 and 2 (each within the scatter of the next). At a limit, above all of these: compound 4.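

Compound 4 gave a limit and not a number: the limit of > 1000 nM in this assay, at which 1 of the 4 values shown sits.

Earlier, butyl and ethyl on this aromatic carbon could not be told apart, so chain length seemed to make no difference here, but the branched isobutyl chain does separate from both straight chains, with an at least 2.2-fold higher number from compound 1 to compound 4 (0.34 log units; beyond the scatter) and an at least 2.0-fold higher number from compound 2 to compound 4 (0.31 log units; beyond the scatter). Isobutyl in place of bromo gave an at least 7.6-fold higher number from compound 3 to compound 4 (0.88 log units; beyond the scatter), so in this assay the choice of group at this position, para to a large group, can weaken inhibition more than the straight chains did, though this rests on one branched compound.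

From the compounds shown here alone, the true size of these steps stays unknown, as each has only a lower bound. Going by these compounds, whether a tert-butyl group or a smaller halogen such as chloro would sit nearer isobutyl or bromo remains open.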